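This account rests on a few compounds, and the source may have more. Where it says the series, first, only, none or still open, it means among the compounds named here.

Three compounds share one core and differ only in the group on a saturated chain carbon bound to a carbonyl carbon and an oxygen, or in a methyl on that group: compound 1 `Cc1cccc([C@@H](O)C(=O)N2N=CC[C@H]2C(=O)NCc2cc(Cl)ccc2-n2cnnn2)c1`, compound 2 `O=C(NCc1cc(Cl)ccc1-n1cnnn1)[C@@H]1CC=NN1C(=O)[C@H](O)c1ccccc1` and compound 3 `CC(C)CC[C@@H](O)C(=O)N1N=CC[C@H]1C(=O)NCc1cc(Cl)ccc1-n1cnnn1`. All were tested in an ADME assay on liver for metabolic stability, with Liver microsome (Homo sapiens) as the target, read by LC-MS, using microsomes; on this read-out higher numbers stand for fast clearance and lower numbers for slow clearance. Compound 1 gives < 12 mL.min-1.g-1, which is a limit of the assay and not a number. Compound 2 gives < 12 mL.min-1.g-1, also a limit. Going by the values given here, compound 3 gives 47 mL.min-1.g-1, the only true number of the set and the highest reading.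

Isopentyl in place of 3-methylphenyl gives an at least 3.9-fold higher number from compound 1 to compound 3 (0.59 log units; beyond the scatter), and isopentyl in place of phenyl gives an at least 3.9-fold higher number from compound 2 to compound 3 (0.59 log units; beyond the scatter). Hydrogen in place of methyl on an aromatic carbon gives a step that the two limits leave unreadable from compound 1 to compound 2.

Compound 4 `O=C(NCc1cc(Cl)ccc1-n1cnnn1)[C@@H]1CC=NN1C(=O)[C@H](O)C1CCCCC1` has cyclohexyl in place of isopentyl on a saturated chain carbon bound to a carbonyl carbon and an oxygen on a saturated carbon. Among the compounds with values here, no measured step covers this exact swap. Its group is a ring, as in compound 1 and compound 2, but a non-aromatic one, so the expectation falls between the readings of compound 1 and compound 2 and that of compound 3 at 47 mL.min-1.g-1. In this assay, the expected change is a modest fall, a 2.4-fold lower number from compound 3 to compound 4 (0.37 log units; beyond the scatter). Compound 4 might also be reported only as the limit of < 12 mL.min-1.g-1 in this assay, at which 2 of the 3 values shown sit. Compound 4 is estimated at 20 mL.min-1.g-1, with an expected range from 12 mL.min-1.g-1 to 45 mL.min-1.g-1.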

Compound 4, intrinsic clearance in microsomes: 63 mL.min-1.g-1
Beside the measured number, compound 4's estimate is 3.2-fold (0.50 log units) below it, and the stated range ends below it.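

In this assay, moving from isopentyl to cyclohexyl gives a 1.3-fold higher number from compound 3 to compound 4 (0.13 log units; within the scatter), so these two groups cannot be told apart on this read-out, and a ring at this position does not by itself go with a low reading. Cyclohexyl in place of the aromatic rings gives an at least 5.2-fold higher number from compound 2 to compound 4 (0.72 log units; beyond the scatter) and an at least 5.2-fold higher number from compound 1 to compound 4 (0.72 log units; beyond the scatter), so within these four compounds the readings divide between the aromatic groups, phenyl and 3-methylphenyl, and the non-aromatic groups, isopentyl and cyclohexyl. These last two steps give only a minimum size, because each starts from a reading that is a limit of the assay and not a number: the limit of < 12 mL.min-1.g-1 in this assay, at which 2 of the 4 values shown sit.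

The compounds shown leave open whether an aromatic ring containing nitrogen, such as pyridyl, would read with phenyl or with cyclohexyl. They also leave open how far a hydroxyl group on the cyclohexyl ring, or a much shorter chain such as methyl, would move the reading in this assay.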